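The source may report more compounds than this note shows. Statements on the series, on what has been measured and on what is new or still open speak of the compounds shown alone.

Of the compounds shown here, three have been measured in a functional assay on PC-12 cells (Rattus norvegicus) for cytotoxicity, read by MTT assay, with stated times of 3 h and 2 h, tested at 20 uM (a lower number here means a weaker effect, a higher number a stronger effect of the compound at the concentration tested), so far. Compound 1 `O=C(CCCCC1CCSS1)NCc1cn(CCCCOc2ccc3ccc(=O)oc3c2)nn1` gives 69.8%. Compound 2 `O=C(CCCCC1CCSS1)NCc1cn(CCCCOc2ccc3cc(-c4ccccc4)c(=O)oc3c2)nn1` gives 26%, and compound 3 `COc1ccc(-c2cc3ccc(OCCCCn4cc(CNC(=O)CCCCC5CCSS5)nn4)cc3oc2=O)cc1` gives 52.3%. Compound 3 thus stands second highest of the three, with compound 1 above it by a number 17.5 percentage points lower from compound 1 to compound 3 (beyond the scatter) and compound 2 below it by a number 26.3 percentage points higher from compound 2 to compound 3 (beyond the scatter). Compound 4 `O=C(CCCCC1CCSS1)NCc1cn(CCCCOc2ccc3cc(-c4ccc(Br)cc4)c(=O)oc3c2)nn1` differs from compound 3 as bromo in place of methoxy on an aromatic carbon. Within the data shown here, the step bearing on this is the one from compound 2 to compound 3, a number 26.3 percentage points higher from compound 2 to compound 3 (beyond the scatter), since compound 4 likewise lacks the methoxy; the bromo has no precedent here. A modest decrease is therefore expected, a number 17.3 percentage points lower from compound 3 to compound 4 (beyond the scatter). For compound 4 the estimate in this assay is 35%, within 20% to 55%.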

Compound 4, a percentage reported as activity, at one concentration (the size of the read-out at that concentration, not a potency): 45%
Estimate against measurement, compound 4: 10 percentage points below; measured number inside the range.
By their numbers in this assay, from the lowest: compound 2; then compounds 4 and 3 (each within the scatter of the next); then compound 1.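

In this assay, the exchange of methoxy for bromo on this ring makes no difference that can be read, a number 7.3 percentage points lower from compound 3 to compound 4 (within the scatter). Bromo in place of hydrogen at the same place also lifts the number, a number 19 percentage points higher from compound 2 to compound 4 (beyond the scatter), so this gain is not confined to methoxy, yet the 4-bromophenyl group still leaves the number short of hydrogen on the core, a number 24.8 percentage points lower from compound 1 to compound 4 (beyond the scatter). Nothing at hand accounts for these steps.

Open, from the compounds shown here alone, is whether an amine or a carboxylic acid at this place would follow bromo and methoxy, or stay nearer the unsubstituted phenyl.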